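Fluoro to hydrogen on a weakly active cyano nucleoside

The source may hold more compounds than are shown below. What is called first, only, known or untested is meant among the compounds shown, and "the series" means these compounds.

Compound 1 `Cc1cn([C@@H]2O[C@H](CO)[C@@H](O)[C@@](O)(C#N)[C@H]2O)c(=O)nc1O`: 539000 nM
Compound 2 `N#C[C@]1(O)[C@H](O)[C@@H](CO)O[C@@H](n2ccc(N)nc2=O)[C@@H]1O`: 147000 nM
Compound 3 `N#C[C@H]1[C@@H](O)[C@H](n2cc(F)c(O)nc2=O)O[C@H](CO)[C@H]1O`: 550000 nM

In a functional assay on L1210 cells (Mus musculus) (a lower number here means a stronger inhibitor, a higher number a weaker inhibitor), compound 3 gives 550000 nM, the highest of the three numbers. Its value and that of compound 1, 539000 nM, lie within the scatter of each other, so no order can be read between them. Compound 2, with 147000 nM, stands apart with the lowest number, beyond the scatter from compound 3.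

Compound 4 `N#C[C@H]1[C@@H](O)[C@H](n2ccc(O)nc2=O)O[C@H](CO)[C@H]1O` has not yet been measured. It differs from compound 3 in one place: hydrogen in place of fluoro on an aromatic carbon. For the measured compounds named here, no pair of measured compounds shows this change directly, so the step has to be guessed. Going by the values given here, all three measured compounds are weak, and with no step to lean on, the expectation is for compound 4 to stay near compound 3 or to give a somewhat higher number, with the step from compound 3 to compound 4 expected as a 1.6-fold higher number from compound 3 to compound 4 (0.21 log units; within the scatter). Compound 4 is therefore estimated at 900000 nM, within a range from 300000 nM to 3000000 nM.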

Compound 4, half-maximal inhibitory concentration: > 500000 nM
Compound 4 ended at the assay's limit (the forecaster's own chance of this, stated with the estimate: 25%); the middle value does not contradict the limit.
By their numbers in this assay, from the lowest: compound 2; then compounds 1 and 3 (each within the scatter of the next).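

In this assay compound 4 gives > 500000 nM, which is a limit of the assay and not a number. No step can be read from compound 3 to compound 4. The compounds shown leave open whether hydrogen in place of fluoro on an aromatic carbon changes the number in this assay at all.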